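Reaching Toward a Ring Where a Primary Amide Stood

A few compounds are considered here, and "the series" means these few. Any claim that something is new, unique, unknown or untested is made for them only; others in the source may bear on it.

Compound 1 `CC(C)C[C@H](N)c1cc(C(F)(F)F)ccc1N1CCN(C(=O)COc2ccc(O)cc2)CC1` gives 4600 nM in an assay on HEK293 cells for displacement of a labelled ligand from Melanocortin receptor 4 (Homo sapiens); on this read-out lower numbers stand for stronger inhibition and higher numbers for weaker inhibition.
Compound 2 `CC(C)C[C@H](N)c1cc(C(F)(F)F)ccc1N1CCN(C(=O)COc2ccc3ccccc3c2)CC1` gives 2000 nM in this assay.
Compound 3 `CC(C)C[C@H](N)c1cc(C(F)(F)F)ccc1N1CCN(C(=O)CCC(N)=O)CC1` reaches only the limit of > 10000 nM in this assay, which is a limit of the assay and not a number.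

Compound 3 therefore stands at the weak end of the three, since the value sits at the limit of > 10000 nM in this assay, at which 1 of the 3 values shown sits. The change to compound 4 `CC(C)C[C@H](N)c1cc(C(F)(F)F)ccc1N1CCN(C(=O)CCC(=O)c2ccc(Cl)cc2)CC1` is 4-chlorophenyl in place of amino on a carbonyl carbon. Going by the values given here, two measured steps bear on it: an at least 2.1-fold higher number from compound 1 to compound 3 (0.33 log units; beyond the scatter) and an at least 5.0-fold higher number from compound 2 to compound 3 (0.69 log units; beyond the scatter), both showing that an aromatic ring on the chain gave a lower number than the carbamoylmethyl of compound 3. Read the other way, the entry of a 4-chlorophenyl on the carbonyl carbon is expected to lower the number again, though the aryl now sits on a carbonyl carbon rather than on an oxygen, so the size is uncertain. Compound 4 is therefore expected at 3000 nM, within 800 nM to 10000 nM. This estimate means an expected step of an at least 3.3-fold lower number from compound 3 to compound 4 (0.52 log units; beyond the scatter).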

Compound 4, inhibition constant: 820 nM
Compound 4: middle estimate off by 3.7-fold (0.56 log units), on the high side; measured number inside the range.
By their numbers in this assay, from the lowest: compound 4; then compound 2; then compound 1. At a limit, above all of these: compound 3.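

In this assay, 4-chlorophenyl in place of amino on the carbonyl carbon gives an at least 12-fold lower number from compound 3 to compound 4 (1.08 log units; beyond the scatter), so this end of the chain responds strongly to a ring even when that ring sits on a carbonyl carbon rather than on an oxygen. The ring-bearing chain of compound 4 also improves on both oxygen-linked chains, with a 2.4-fold lower number from compound 2 to compound 4 (0.39 log units; beyond the scatter) and a 5.6-fold lower number from compound 1 to compound 4 (0.75 log units; beyond the scatter), which makes compound 4 the strongest of the four in this assay. Compound 3 sits at a limit of the assay and not at a number, so the true size of its step stays unknown: the limit of > 10000 nM in this assay, at which 1 of the 4 values shown sits.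

These last two comparisons change the link and the ring together, so the share of each remains unclear. A plain phenyl, a 4-fluorophenyl or a 4-methoxyphenyl on the same carbonyl carbon would show how much depends on the chlorine.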